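A chloro compound follows a nitro compound

This account rests on a few compounds, and the source may have more. Where it says the series, first, only, none or still open, it means among the compounds named here.

Compound 1 (`COc1ccc(/C=C2\SC(=O)N(CC(=O)Nc3c(C)n(C)n(-c4ccccc4)c3=O)C2=O)cc1`): 75600 nM
Compound 2 (`Cc1c(NC(=O)CN2C(=O)S/C(=C\c3ccc([N+](=O)[O-])cc3)C2=O)c(=O)n(-c2ccccc2)n1C`): 82400 nM

Going by the values given here, in a functional assay on MCF7 cells (Homo sapiens) for inhibition, read by MTT assay, with a stated time of 48 h (on this read-out lower numbers stand for stronger inhibition and higher numbers for weaker inhibition), compound 2 stands level with compound 1, and the only measured step (a 1.1-fold higher number from compound 1 to compound 2 (0.04 log units; within the scatter)) stays within the scatter. Compound 3 (`Cc1c(NC(=O)CN2C(=O)S/C(=C\c3ccc(Cl)cc3)C2=O)c(=O)n(-c2ccccc2)n1C`) carries chloro in place of nitro on an aromatic carbon. Among the compounds with values here, that one step, nitro in place of methoxy on an aromatic carbon, is the only guide, so no shift beyond the scatter is expected (a 1.1-fold lower number from compound 2 to compound 3 (0.06 log units; within the scatter)). The estimate for compound 3 is 72000 nM (expected range 36000 nM to 140000 nM).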

Compound 3, half-maximal inhibitory concentration: 42600 nM
Beside the measured number, compound 3's estimate is 1.7-fold (0.23 log units) above it, within the range that was stated.
By their numbers in this assay, from the lowest: compounds 3, 1 and 2 (each within the scatter of the next).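

On the aromatic carbon para to a large group, this assay now covers a third substituent: chloro in place of nitro gives a 1.9-fold lower number from compound 2 to compound 3 (0.29 log units; within the scatter) and chloro in place of methoxy gives a 1.8-fold lower number from compound 1 to compound 3 (0.25 log units; within the scatter) on the same core. Methoxy, nitro and chloro therefore cannot be told apart at this position, and every pair among the three stays within the scatter. No independent measurement accompanies these numbers to account for them. On these data alone, whether an amine or a carboxylic acid at this position would move the number beyond the scatter remains open.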